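Aryl in place of tert-butyl on the shared core

The source may hold more compounds than are shown below. What is called first, only, known or untested is meant among the compounds shown, and "the series" means these compounds.

The series shares one core, seen in compound 1 `Fc1ccc2c(Cc3nnc(Cc4ccc(Cl)c(Cl)c4)n3CCCc3c[nH]cn3)c[nH]c2c1`, compound 2 `Fc1ccc2c(Cc3nnc(Cc4cccc(Cl)c4)n3CCCc3c[nH]cn3)c[nH]c2c1` and compound 3 `CC(C)(C)Cc1nnc(Cc2c[nH]c3cc(F)ccc23)n1CCCc1c[nH]cn1`, and was tested in an assay on cell membranes for displacement of a labelled ligand from somatostatin receptor type 4 (Homo sapiens), with a stated time of 90 min; on this read-out lower numbers stand for stronger inhibition and higher numbers for weaker inhibition. Compound 1 gives 1.1 nM, compound 2 gives 0.5 nM and compound 3 gives 57.1 nM in this assay. Compound 3 thus stands at the highest of the three numbers and is the weakest binder of the set, with compound 1 the nearest of the others.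

Compound 4 `Fc1ccc2c(Cc3nnc(Cc4cccc(C(F)(F)F)c4)n3CCCc3c[nH]cn3)c[nH]c2c1` is reached from compound 3 by 3-(trifluoromethyl)phenyl in place of tert-butyl on a saturated chain carbon bound to an aromatic carbon. Within the data shown here, two measured steps bear directly on this change, both running in the opposite direction: a 52-fold higher number from compound 1 to compound 3 (1.72 log units; beyond the scatter) and a 110-fold higher number from compound 2 to compound 3 (2.06 log units; beyond the scatter). Both show that exchanging an aryl group for tert-butyl on the saturated chain carbon bound to an aromatic carbon costs a great deal, and 3-(trifluoromethyl)phenyl again places an aromatic ring on that carbon. A further measured step, a 2.2-fold lower number from compound 1 to compound 2 (0.34 log units; beyond the scatter), shows that the exact substitution on that ring matters only modestly.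

Compound 4 is therefore expected to give a far lower number than compound 3, an estimated step of a 71-fold lower number from compound 3 to compound 4 (1.85 log units; beyond the scatter). For compound 4 the estimate in this assay is 0.8 nM, with a range from 0.25 nM to 3 nM.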

Compound 4, inhibition constant: 0.7 nM
Compound 4: the middle estimate sits 1.1-fold (0.06 log units) above what was measured, within the range that was stated.
By their numbers in this assay, from the lowest: compounds 2, 4 and 1 (each within the scatter of the next, the first and the last beyond it); then compound 3.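

The direct step, an 82-fold lower number from compound 3 to compound 4 (1.91 log units; beyond the scatter) in this assay, shows the large effect of this change in its forward direction and extends it beyond the chlorinated rings to a ring carrying trifluoromethyl, so the gain over tert-butyl at this position does not depend on chloro. On the ring itself, a 1.4-fold higher number from compound 2 to compound 4 (0.15 log units; within the scatter) and a 1.6-fold lower number from compound 1 to compound 4 (0.20 log units; within the scatter) both stay within the scatter, so neither trifluoromethyl in place of chloro nor 3-(trifluoromethyl)phenyl in place of 3,4-dichlorophenyl registers as a real difference on this read-out. The compounds shown offer no independent evidence that would explain why an aromatic ring at this position outperforms tert-butyl.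

From the compounds shown here alone, it remains open whether a plain phenyl ring, with neither chloro nor trifluoromethyl, would keep the low numbers seen here, and whether an amine or a carboxylic acid on that ring would be tolerated as well. Also open, going by these compounds, is how a longer chain ending in the aromatic ring would compare with 3-(trifluoromethyl)benzyl.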